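From 4-chlorophenyl to 2,4-difluorophenyl in growth inhibition

A few compounds are considered here, and "the series" means these few. Any claim that something is new, unique, unknown or untested is made for them only; others in the source may bear on it.

Measured in a functional assay on UACC-62 cells (Homo sapiens); a higher number here means a weaker inhibitor of growth, a lower number a stronger inhibitor of growth:
compound 1 `O=S(=O)(/C=C/c1ccc(Br)cc1)Cc1ccc(Nc2ncnc3ccccc23)cc1` gives > 100000 nM, which is a limit of the assay
compound 2 `O=S(=O)(/C=C/c1ccc(Cl)cc1)Cc1ccc(Nc2ncnc3ccccc23)cc1` gives 13000 nM
compound 3 `O=S(=O)(/C=C/c1ccc(Cl)cc1)Cc1ccc(Nc2ncnc3ccc(Br)cc23)cc1` gives 15000 nM

Compound 3, at 15000 nM, stands level with compound 2, at 13000 nM, and the step of a 1.2-fold higher number from compound 2 to compound 3 (0.06 log units; within the scatter) lies within the scatter. Both carry the 4-chlorophenyl group. Compound 4 `O=S(=O)(/C=C/c1ccc(F)cc1F)Cc1ccc(Nc2ncnc3ccc(Br)cc23)cc1` keeps the rest of compound 3 and exchanges that group: 2,4-difluorophenyl in place of 4-chlorophenyl on a double-bonded chain carbon bound to a double-bonded chain carbon. The measured step closest to this change is an at least 7.6-fold lower number from compound 1 to compound 2 (0.88 log units; beyond the scatter), a swap of one halogen on the same ring that lies beyond the scatter. Within the data shown here, it shows that this ring can matter in this assay, but no measured compound carries fluorine, so it fixes neither the size nor the direction of the new change. A small move towards a higher number is expected, probably not clearly beyond the scatter, with a real chance of a much weaker result.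

The expected step is a 1.3-fold higher number from compound 3 to compound 4 (0.12 log units; within the scatter).

For compound 4 the estimated value is 20000 nM, with an expected range from 6000 nM to 70000 nM.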

Compound 4, concentration for 50% growth inhibition: 3000 nM
Beside the measured number, compound 4's estimate is 6.7-fold (0.82 log units) above it; the measured number lies below the stated range.
By their numbers in this assay, from the lowest: compound 4; then compounds 2 and 3 (each within the scatter of the next). At a limit, above all of these: compound 1.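

The exchange of 4-chlorophenyl for 2,4-difluorophenyl gives a 5.0-fold lower number from compound 3 to compound 4 (0.70 log units; beyond the scatter) in this assay, which shows that this ring can carry fluorine in place of chlorine and still lower the number. Compounds 2 and 3 had shown no step beyond the scatter when the core changed, and here a change on the ring alone gives such a step on the core of compound 3. Nothing given here accounts for the size of this step.

As far as these compounds go, the change removes one chlorine and brings in two fluorines at once, so the share of each fluorine stays open, and 4-fluorophenyl or 2-fluorophenyl would each bear on that question. Also open, from the compounds shown here alone, is whether 2,4-difluorophenyl gives a similar step on the core of compound 2, which lacks the bromo group.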